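The compounds below may be only part of what the source reports. "The series", "measured", "known", "first", "only" and "open" are said of these compounds alone.

Three esters built on a small saturated ring-bearing alcohol or a related diol have been measured in an assay on membranes from cerebellum for inhibition of Monoglyceride lipase (Rattus norvegicus), tested at 100 uM; on this read-out lower numbers stand for less inhibition and higher numbers for more inhibition at the one concentration tested (going by the name of the read-out). Compound 1, `O=C(OCC1CCCCO1)c1ccccc1`, carries a plain benzoyl group and in this assay gives 24%. Compound 2, `CCCCC/C=C\C/C=C\C/C=C\C/C=C\CCCC(=O)OC[C@@H]1COC(C)(C)O1`, is an ester of a long polyunsaturated fatty acid and gives 38%. Compound 3, `CCCCCCCC/C=C\CCCCCCCC(=O)OCC1CCCCO1`, is an ester of a long singly unsaturated fatty acid and gives 35%. Compound 1 therefore stands lowest of the three numbers; compound 3 is nearest to it, a number beyond the scatter above it, and compound 2 lies furthest, also beyond the scatter.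

The next compound, compound 4, `O=C(OCC1CCCCO1)c1cccc(-c2ccccc2)c1`, differs from compound 1 in one place: phenyl in place of hydrogen on an aromatic carbon. Among the compounds with values here, no pair of measured compounds mirrors this change, so no measured step can be leaned on. Given that compound 1 gives 24% while the two esters with larger acid portions, compound 2 and compound 3, give higher numbers, a modest rise is expected, and the step of a number 11 percentage points higher from compound 1 to compound 4 (beyond the scatter) is the estimate. Compound 4 is expected to give about 35%, most likely between 15% and 55%.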

Compound 4, a percentage reported as inhibition, at one concentration (the size of the read-out at that concentration, not a potency): 49%
Estimate against measurement, compound 4: 14 percentage points below; measured number inside the range.
By their numbers in this assay, from the lowest: compound 1; then compounds 3 and 2 (each within the scatter of the next); then compound 4.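

In this assay, within the data shown here, putting phenyl in place of hydrogen on an aromatic carbon, meta to a large group, gives a number 25 percentage points higher from compound 1 to compound 4 (beyond the scatter) and provides the first direct comparison of two compounds that differ in one place. This shows that the position can carry a second six-membered aromatic ring of carbon only, adding 6 heavy atoms, and that inhibition at the one tested concentration rises rather than falls. No separate measurement bears on the reason for this rise, so the result records what changed but not why.

Going by these compounds, it remains open whether a small methyl group, a methoxy group, or a saturated cyclohexyl ring at the same carbon would move the number in the same way, or whether the aromatic ring of the phenyl group matters at all. On these data alone, it is also open whether phenyl on another carbon of the same aromatic ring would give a similar result, and a number from one concentration cannot say how potent compound 4 is.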